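The compounds below may be only part of what the source reports. "The series", "measured", "known", "first", "only" and "open" are said of these compounds alone.

Compound 1, `O=C(Nc1ccc(Oc2cccc(C(F)(F)F)c2)cc1)c1c(F)cccc1Cl`, gives 2410 nM in an assay on HEK293 cells for inhibition of Toll-like receptor 8 (Homo sapiens), with a stated time of 16 h; a lower number here means a stronger inhibitor, a higher number a weaker inhibitor. Compound 2, `O=C(Nc1ccc(Oc2cc(Br)cc(C(F)(F)F)c2)cc1)c1c(F)cccc1Cl`, gives 2320 nM in this assay. Going by the values given here, the one change between them, a bromo in place of a hydrogen on an aromatic carbon, produced a 1.0-fold lower number from compound 1 to compound 2 (0.02 log units; within the scatter), so the two values lie within the usual scatter of each other, and compound 2 stands level with compound 1 on the numbers seen so far.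

Compound 3, `O=C(Nc1ccc(Oc2cc(I)cc(C(F)(F)F)c2)cc1)c1c(F)cccc1Cl`, differs from compound 2 by iodo in place of bromo on an aromatic carbon. Among the compounds with values here, the only measured step that bears on this change is the one at the same position, from compound 1 to compound 2, which stayed within the scatter. On that basis, swapping one halogen for another at this position is expected to give a 1.0-fold lower number from compound 2 to compound 3 (0.00 log units; within the scatter) in this assay, no change beyond the scatter. Compound 3 is therefore estimated at 2300 nM in this assay, within a range from 1150 nM to 4600 nM.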

Compound 3, half-maximal inhibitory concentration: 5000 nM
Beside the measured number, compound 3's estimate is 2.2-fold (0.34 log units) below it; measured number outside the range, above it.
By their numbers in this assay, from the lowest: compounds 2 and 1 (each within the scatter of the next); then compound 3.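

This position is not indifferent to what sits on it. Bromo stood level with hydrogen in this assay, yet iodo in place of bromo gives a 2.2-fold higher number from compound 2 to compound 3 (0.33 log units; beyond the scatter) and iodo in place of hydrogen gives a 2.1-fold higher number from compound 1 to compound 3 (0.32 log units; beyond the scatter) in the same direction, so the earlier flat step did not hold for every halogen here. No available evidence explains why iodo and bromo part ways at this position, although each is a single heavy atom with no hydrogen-bond donors or acceptors.

The compounds shown leave open how a different group at this position, such as an amine, a nitrile or a methoxy group, would read, and whether any of them would lower the number. They also leave open whether iodo in place of bromo would give a step of this size on a different core.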